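Methyl in Place of Hydrogen on the Saturated Ring

The compounds below may be only part of what the source reports. "The series", "measured", "known", "first", "only" and "open" are said of these compounds alone.

Compound 3 `COc1cc2c(Oc3ccc(NC(=O)c4nn(-c5ccc(Cl)cc5Cl)c(=O)cc4C)cc3F)ccnc2cc1OCCCN1CCCCC1` gives 80 nM in a functional assay on MKN-45 cells (Homo sapiens) for inhibition, read by MTT assay, with a stated time of 72 h; a lower number here means a stronger inhibitor, a higher number a weaker inhibitor. Among the three measured compounds it holds the second highest number: compound 1 `COc1cc2c(Oc3ccc(NC(=O)c4nn(-c5ccccc5C(F)(F)F)c(=O)cc4C)cc3F)ccnc2cc1OCCCN1CCC(C)CC1` gives 60 nM, which lies within the scatter of compound 3, and compound 2 `COc1cc2c(Oc3ccc(NC(=O)c4nn(-c5ccc(Cl)cc5)c(=O)cc4C)cc3F)ccnc2cc1OCCCN1CCC(C)CC1` gives 150 nM, also within the scatter of compound 3. Within the data shown here, the only measured step, a 2.5-fold higher number from compound 1 to compound 2 (0.40 log units; beyond the scatter), concerns the aryl group on the aromatic nitrogen and not the saturated ring. Compound 4 `COc1cc2c(Oc3ccc(NC(=O)c4nn(-c5ccc(Cl)cc5Cl)c(=O)cc4C)cc3F)ccnc2cc1OCCCN1CCC(C)CC1` differs from compound 3 only by methyl in place of hydrogen on a saturated ring carbon. Among the measured compounds shown here, no measured step touches this change, so nothing here points to a shift beyond the scatter. Compound 4 is therefore expected to give about 80 nM, with a range from 40 nM to 160 nM. The expected step of no change at the digits printed from compound 3 to compound 4 (within the scatter) is estimated to stay within the scatter.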

Compound 4, half-maximal inhibitory concentration: 120 nM
The estimate for compound 4 lay 1.5-fold (0.18 log units) below the measured number; low and high end bracket the measured number.
By their numbers in this assay, from the lowest: compounds 1, 3, 4 and 2 (each within the scatter of the next, the first and the last beyond it).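

In this assay, among these compounds, the change from piperidin-1-yl to 4-methylpiperidin-1-yl gives a 1.5-fold higher number from compound 3 to compound 4 (0.18 log units; within the scatter) and so stays within the scatter at this ring carbon, which no earlier step had tested. With the methyl present, chloro in place of hydrogen gives a 1.3-fold lower number from compound 2 to compound 4 (0.10 log units; within the scatter) and 2,4-dichlorophenyl in place of 2-(trifluoromethyl)phenyl gives a 2.0-fold higher number from compound 1 to compound 4 (0.30 log units; within the scatter) as well, so both of these aryl changes also stay within the scatter. No measurement at hand explains any of these steps. The compounds shown leave open whether an ethyl, a hydroxyl or a dimethylamino group on this ring carbon would stay within the scatter. They also leave open what a morpholine in place of the piperidine would give.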